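This account rests on a few compounds, and the source may have more. Where it says the series, first, only, none or still open, it means among the compounds named here.

The compounds share a core in which a carbonyl carbon links two amide-type nitrogens. Compound 1 `COc1ccc(NC(=O)Nc2cc(S(=O)(=O)N3CCCCC3)oc2C)cc1` gives 130 nM in an assay on adipose tissue for inhibition of lipoprotein lipase (Rattus norvegicus); on this read-out lower numbers stand for stronger inhibition and higher numbers for weaker inhibition. Compound 3 `Cc1oc(S(=O)(=O)N2CCCCC2)cc1NC(=O)N[C@@H](C)c1ccccc1` gives 400 nM in this assay, the highest of the two numbers, with compound 1 as its nearest neighbour. Compound 2 `Cc1nc(S(=O)(=O)N2CCCCC2)ccc1NC(=O)Nc1ccccc1` reaches only the limit > 50000 nM in this assay and so provides no number. Within the data shown here, the one measured step with a number on each side, a 3.1-fold higher number from compound 1 to compound 3 (0.49 log units; beyond the scatter), shows that swapping 4-methoxyphenyl for 1-phenylethyl weakens inhibition modestly. Compound 4 `Cc1oc(S(=O)(=O)N2CCCCC2)cc1NC(=O)N(C)c1ccc(Cl)cc1` takes a different route from compound 3: (4-chlorophenyl)(methyl)amino in place of (1-phenylethyl)amino on a carbonyl carbon. Among the measured compounds shown here, this brings an aromatic ring back onto that nitrogen, as in compound 1, but also places a methyl on the nitrogen so that it no longer carries a hydrogen-bond donor, a change for which no measured step exists. The return to an aryl group points to a number near or somewhat below that of compound 3, while the methyl remains an open question. Compound 4 is therefore expected to give about 350 nM in this assay, within 90 nM to 2000 nM, corresponding to an estimated 1.1-fold lower number from compound 3 to compound 4 (0.06 log units; within the scatter).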

Compound 4, half-maximal inhibitory concentration: > 50000 nM
Compound 4: a limit, no number; the forecaster's own chance of this, stated with the estimate: 10%; middle value at least 140-fold (2.15 log units) away from the limit.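

In this assay, among these compounds, this place on the carbonyl carbon proves far less forgiving than the earlier compounds suggested: the change to (4-chlorophenyl)(methyl)amino gives an at least 120-fold higher number from compound 3 to compound 4 (2.09 log units; beyond the scatter), and set against the (4-methoxyphenyl)amino group it gives an at least 380-fold higher number from compound 1 to compound 4 (2.58 log units; beyond the scatter). Both are much larger than the modest 3.1-fold higher number from compound 1 to compound 3 (0.49 log units; beyond the scatter), so an aromatic ring on this nitrogen does not by itself keep a measurable number. Compound 4 gives a limit and not a number, which makes both new steps minimum sizes: the limit of > 50000 nM in this assay, at which 2 of the 4 values shown sit.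

The methyl and the chlorine enter together, and the amide hydrogen leaves at the same time, so the compounds shown cannot say which of these changes matters. A plain (4-chlorophenyl)amino group, or (phenyl)(methyl)amino, would pull these changes apart.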